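A few compounds are considered here, and "the series" means these few. Any claim that something is new, unique, unknown or untested is made for them only; others in the source may bear on it.

In a functional assay on K562 cells (Homo sapiens) for cytotoxicity, read by propidium iodide staining, with a stated time of 48 h (a higher number here means that more compound is tolerated, a lower number that less compound is tolerated), compound 1 `O=C(CN1C(=O)S/C(=C/c2ccco2)C1=O)Nc1ccc(Br)cc1` gives 94000 nM and compound 2 `O=C(CN1C(=O)S/C(=C/c2ccco2)C1=O)Nc1nc2ccccc2s1` gives 91900 nM, so the two compounds stand level within the usual scatter. Compound 3 `Cc1cccc2sc(NC(=O)CN3C(=O)S/C(=C/c4ccco4)C3=O)nc12` differs from compound 2 by one small edit, (methyl in place of hydrogen on an aromatic carbon), which is methyl in place of hydrogen on an aromatic carbon. Within the data shown here, no measured pair yet shows what this change does, so the expectation starts from compound 2 at 91900 nM. The expected step, a 1.1-fold lower number from compound 2 to compound 3 (0.03 log units; within the scatter), stays within the scatter, with no clear direction. Compound 3 is estimated at 85000 nM, with an expected range from 40000 nM to 130000 nM.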

Compound 3, half-maximal cytotoxic concentration: 97100 nM
For compound 3 the middle estimate is 1.1-fold (0.06 log units) below the measured one; the measured number falls inside the stated range.
By their numbers in this assay, from the lowest: compounds 2, 1 and 3 (each within the scatter of the next).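

Placing methyl in place of hydrogen on an aromatic carbon, ortho to a fused ring and meta to a fused ring, brings a 1.1-fold higher number from compound 2 to compound 3 (0.02 log units; within the scatter) in this assay, so this first read of the change shows compound 3 level with compound 2. No other data here bear on why the two stand level.

Going by these compounds, whether another group at this position, such as an amine or a carboxylic acid, would also leave the number level stays open. So does whether methyl on another carbon of this ring would do the same.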